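This account rests on a few compounds, and the source may have more. Where it says the series, first, only, none or still open, it means among the compounds named here.

Measured so far:
- compound 1 `CCCCOc1nc(N)c2ncn([C@@H]3O[C@H](COP(=O)(O)OP(=O)(O)OP(=O)(O)O)[C@@H](O)[C@H]3O)c2n1`: 88 nM
- compound 2 `CCCCSc1nc2c(N)ncnc2n1[C@@H]1O[C@H](COP(=O)(O)OP(=O)(O)OP(=O)(O)O)[C@@H](O)[C@H]1O`: 10000 nM

Both compounds were tested in an assay on cell membranes with P2Y purinoceptor 1 (Meleagris gallopavo) as the target; on this read-out higher numbers stand for an effect only at larger amounts of compound and lower numbers for an effect already at smaller amounts. Compound 1 gives 88 nM in this assay, and compound 2 gives 10000 nM. Within the data shown here, of the two numbers, compound 2 has the higher one; the gap to compound 1, its only neighbour, lies well beyond the usual scatter, so compound 2 is the compound that needs the larger amount to act. Among the measured compounds shown here, no single-change step connects the two, since they differ in more than one place, so only their two values can be compared.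

Compound 3 `CCCCNc1nc2c(N)ncnc2n1[C@@H]1O[C@H](COP(=O)(O)OP(=O)(O)OP(=O)(O)O)[C@@H](O)[C@H]1O` is not yet measured. It differs from compound 2 in one place: butylamino in place of butylsulfanyl on an aromatic carbon. The sulfur link to the butyl chain is thus exchanged for a nitrogen link that also carries a hydrogen. Nothing in the measured pair shows how such an exchange at this place plays out, and the chain itself keeps its length.

For this reason compound 3 is expected to stay close to compound 2, with the step from compound 2 to compound 3 estimated as no change at the digits printed from compound 2 to compound 3 (within the scatter), not clearly beyond the scatter in either direction. The value expected for compound 3 in this assay is 10000 nM, within a range from 3000 nM to 30000 nM.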

Compound 3, half-maximal effective concentration: 51000 nM
Compound 3: middle estimate off by 5.1-fold (0.71 log units), on the low side, and the stated range ends below it.
By their numbers in this assay, from the lowest: compound 1; then compound 2; then compound 3.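

In this assay, butylamino in place of butylsulfanyl on an aromatic carbon gives a 5.1-fold higher number from compound 2 to compound 3 (0.71 log units; beyond the scatter), so compound 3 needs a larger amount of compound than compound 2 to show its effect. The earlier pair could not show this, as compounds 1 and 2 differ in more than one place, whereas here the butyl chain stays the same and only its link to the ring changes, from sulfur to a nitrogen that also carries a hydrogen; the atom joining the chain to this carbon, between two ring nitrogen atoms, therefore matters on its own. No measurement at hand explains why this exchange moves the number in this direction.

The compounds shown do not separate the effect of the nitrogen atom from that of the hydrogen it carries, a question that a butyl(methyl)amino group, whose nitrogen has no hydrogen, could address. They also leave open how chain length plays out with either link, as hexylamino or hexylsulfanyl at the same place would show.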